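The source may hold more compounds than are shown below. What is called first, only, known or untested is meant among the compounds shown, and "the series" means these compounds.

The measured compounds in an assay on isolated protein for inhibition of Retinaldehyde dehydrogenase 3 (Homo sapiens) (on this read-out lower numbers stand for stronger inhibition and higher numbers for weaker inhibition), are these:
Compound 1, `CC(Sc1nc2c(cnn2C)c(=O)n1-c1ccccc1)c1ccccn1`, gives 89 nM.
Compound 2, `CC(Sc1nc2c(cnn2C)c(=O)n1-c1ccccc1)c1cccnc1`, gives 95 nM.
Compound 3, `CC(Sc1nc2c(cnn2C)c(=O)n1-c1ccccc1)c1cccc(O)c1`, gives 91 nM.

Compound 3 stands second highest of the three numbers, but both of its distances are inside the scatter: a 1.0-fold higher number from compound 1 to compound 3 (0.01 log units; within the scatter) and a 1.0-fold lower number from compound 2 to compound 3 (0.02 log units; within the scatter). Compound 4, `CC(Sc1nc2c(cnn2C)c(=O)n1-c1ccccc1)c1ccccc1`, keeps the same core and the same chain and differs from compound 3 in one place: hydrogen in place of hydroxy on an aromatic carbon, on an aromatic carbon of a six-membered aromatic ring of carbon only. Among the compounds with values here, no measured step removes this group. The steps that exist exchange the whole aryl group at that chain carbon, and every one of them stays within the scatter, a 1.1-fold higher number from compound 1 to compound 2 (0.03 log units; within the scatter) included. Since pyridin-2-yl, pyridin-3-yl and 3-hydroxyphenyl at this position gave numbers in this assay that cannot be told apart, the loss of the hydroxy alone is expected to give a 1.2-fold higher number from compound 3 to compound 4 (0.08 log units; within the scatter), nothing beyond the scatter. Compound 4 is therefore estimated at 110 nM in this assay, with a range from 50 nM to 250 nM.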

Compound 4, half-maximal inhibitory concentration: 73 nM
Estimate against measurement, compound 4: 1.5-fold (0.18 log units) above, and the stated range covers the measured number.
By their numbers in this assay, from the lowest: compounds 4, 1, 3 and 2 (each within the scatter of the next).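

In this assay the plain phenyl group stays level with the other aryl groups at this chain carbon: taking off the hydroxy gives a 1.2-fold lower number from compound 3 to compound 4 (0.10 log units; within the scatter) while phenyl for the two pyridines gives a 1.3-fold lower number from compound 2 to compound 4 (0.11 log units; within the scatter) and a 1.2-fold lower number from compound 1 to compound 4 (0.09 log units; within the scatter) and none of the three leaves the scatter. The earlier compounds shown here all carried a ring nitrogen or a hydroxy on this aryl group, so only now is it seen that neither the hydroxy nor a ring nitrogen is needed for a number in this range. Nothing at hand explains why the four compounds cannot be told apart.

On these data alone, it remains open whether this position accepts anything other than a six-membered aromatic ring, such as a longer chain in place of the aryl group, or a carboxylic acid or an amine on the phenyl ring. As far as these compounds go, whether the same flat picture would hold on a changed core also stays open.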